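This account rests on a few compounds, and the source may have more. Where it says the series, first, only, none or still open, it means among the compounds named here.

In an ADME assay on HepG2 cells (Homo sapiens) for cytotoxicity, read by MTT assay, with a stated time of 48 h (a higher number here means a weaker inhibitor, a lower number a stronger inhibitor), compound 1 `N#CC1=C(N)N2CCCNC2=C([N+](=O)[O-])C12c1ccccc1-c1nc3ccccc3nc12` gives 174000 nM and compound 2 `Cc1cc2nc3c(nc2cc1C)C1(C(C#N)=C(N)N(Cc2ccccc2)C(NCc2ccccc2)=C1[N+](=O)[O-])c1ccccc1-3` gives 174000 nM, so the two stand level. Compound 3 `N#CC1=C(N)N2CCCNC2=C([N+](=O)[O-])C12c1ccccc1-c1nc3ccc([N+](=O)[O-])cc3nc12` keeps the core of compound 1 with a single change, nitro in place of hydrogen on an aromatic carbon. Going by the values given here, no measured pair shows what this swap does in this assay, so any forecast is loose. A modest move towards stronger inhibition is expected, an estimated 1.5-fold lower number from compound 1 to compound 3 (0.16 log units; within the scatter). For compound 3 the expected value is 120000 nM, with an estimated range of 40000 nM to 300000 nM.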

Compound 3, half-maximal inhibitory concentration: 161000 nM
Compound 3: the middle estimate sits 1.3-fold (0.13 log units) below what was measured, and the stated range covers the measured number.
By their numbers in this assay, from the lowest: compounds 3, 1 and 2 (each within the scatter of the next).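

In this assay putting nitro in place of hydrogen on an aromatic carbon gives a 1.1-fold lower number from compound 1 to compound 3 (0.03 log units; within the scatter) and so leaves the reading within the usual scatter. At this place, on a six-membered aromatic ring of carbon only, the shared core therefore tolerates this added group with no readable change in this cytotoxicity measure. Nothing available explains this result. Going by these compounds, whether an amine or a carboxylic acid on the same carbon would read the same remains open, as does whether nitro on another carbon of that ring would.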